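The compounds below may be only part of what the source reports. "The series", "measured", "known", "first", "only" and "open" are said of these compounds alone.

Measured compounds:
Compound 1, `CCn1ncc2c(F)cc(-c3ccc(C(CC)(CC)c4nnc[nH]4)c(=O)[nH]3)cc21`, gives 29 nM in a functional assay on CHO cells for antagonist activity at prostaglandin E2 receptor EP3 subtype (Homo sapiens), read by cAMP accumulation; on this read-out lower numbers stand for stronger inhibition and higher numbers for weaker inhibition.
Compound 2, `CCn1ncc2c(F)cc(-c3ccc(C(CC)(CC)c4nnc(C)[nH]4)c(=O)[nH]3)cc21`, gives 90 nM.
Compound 3, `Cc1nc(C(c2ccc(-c3ccc4cccc(F)c4c3)[nH]c2=O)C(C)C)[nH]c1C`, gives 50 nM.

Compound 3 stands second highest of the three numbers, but its gap to compound 1 and its gap to compound 2 are both within the scatter, so the three cannot be ranked against each other with confidence. Among the compounds with values here, the one step that lies beyond the scatter, a 3.1-fold higher number from compound 1 to compound 2 (0.49 log units; beyond the scatter), concerns methyl in place of hydrogen on an aromatic carbon of the group borne by the chain carbon.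

Compound 4, `CC(C)C(/C=C1/CCNC1=O)c1ccc(-c2ccc3cccc(F)c3c2)[nH]c1=O`, differs from compound 3 at that same chain carbon: a group of 7 heavy atoms (5 carbon, 1 nitrogen, 1 oxygen; one five-membered non-aromatic ring with 1 hetero atom) in place of a group of 7 heavy atoms (5 carbon, 2 nitrogen; one five-membered aromatic ring with 2 hetero atoms), on a saturated chain carbon bound to an aromatic carbon and a saturated chain carbon. Here the 4,5-dimethyl-1H-imidazol-2-yl group leaves and a group with one five-membered non-aromatic ring with one hetero atom and two double bonds outside aromatic rings enters. Within the data shown here, no measured step changes this part of the molecule in this way, so the single step from compound 1 to compound 2 gives only a rough sense that this position is sensitive to alteration. A modest weakening is expected, with wide uncertainty. Compound 4 is therefore expected to give 150 nM, between 40 nM and 600 nM. This expectation amounts to a step of a 3.0-fold higher number from compound 3 to compound 4 (0.48 log units; beyond the scatter).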

Compound 4, half-maximal inhibitory concentration: 8.1 nM
Compound 4: the middle estimate sits 19-fold (1.27 log units) above what was measured; the whole stated range lies above it.
By their numbers in this assay, from the lowest: compound 4; then compounds 1, 3 and 2 (each within the scatter of the next, the first and the last beyond it).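

At the saturated chain carbon bound to an aromatic carbon and a saturated chain carbon, the 4,5-dimethyl-1H-imidazol-2-yl group can give way to a five-membered non-aromatic ring with one hetero atom and two double bonds outside aromatic rings, with a step in this assay of a 6.2-fold lower number from compound 3 to compound 4 (0.79 log units; beyond the scatter). Within the data shown here, the counts of heavy atoms, donors and acceptors are the same in the two groups, so an aromatic ring is not needed here for a low number, whereas the only earlier readable step at this part of the molecule, a 3.1-fold higher number from compound 1 to compound 2 (0.49 log units; beyond the scatter), went the other way. Nothing available explains this gain.

As far as these compounds go, it remains open whether a carboxylic acid or an amine on the same chain carbon would keep the number this low. From the compounds shown here alone, it is equally open whether the entering group would do the same on the core of compound 1.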